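Amide substituent change at the p300 inhibitor amide nitrogen

The source may hold more compounds than are shown below. What is called first, only, known or untested is meant among the compounds shown, and "the series" means these compounds.

Measured compounds:
Compound 1, `O=C1Cc2cc(NC(=O)[C@H]3CCCN3C(=O)C3(c4cccc(Cl)c4)CCCC3)ccc2N1`: 0.794 nM
Compound 2, `O=C(Nc1ccc2[nH]ncc2c1)[C@H]1CCCN1C(=O)C1(c2cccc(Cl)c2)CCCC1`: 1 nM

In an assay on isolated protein for inhibition of histone acetyltransferase p300 (Homo sapiens), with a stated time of 60 min (a higher number here means a weaker inhibitor, a lower number a stronger inhibitor), compound 2 stands at the higher of the two numbers, and compound 1 sits nearest, the pair separated by a 1.3-fold higher number from compound 1 to compound 2 (0.10 log units; within the scatter). Compound 3, `CNC(=O)c1ccc(NC(=O)[C@H]2CCCN2C(=O)C2(c3cccc(Cl)c3)CCCC2)cc1`, differs from compound 2 by 4-(methylcarbamoyl)phenyl in place of 1H-indazol-5-yl on an amide-type nitrogen. Within the data shown here, the one measured step, from compound 1 to compound 2, concerns the same position and was within the scatter, but it exchanged two groups each with a five-membered ring and a six-membered ring, whereas the group entering in compound 3 has a single six-membered aromatic ring. Compound 3 is therefore expected to give a modestly weaker result, a step of a 3.0-fold higher number from compound 2 to compound 3 (0.48 log units; beyond the scatter), with an estimate of 3 nM and a range from 0.8 nM to 12 nM.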

Compound 3, half-maximal inhibitory concentration: 0.794 nM
Estimate against measurement, compound 3: 3.8-fold (0.58 log units) above, outside the stated range (below it).
By their numbers in this assay, from the lowest: compounds 1, 3 and 2 (each within the scatter of the next).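

In this assay, the exchange on the amide-type nitrogen gives a 1.3-fold lower number from compound 2 to compound 3 (0.10 log units; within the scatter), and the other comparison gives no change at the digits printed from compound 1 to compound 3 (within the scatter). A group with only a six-membered aromatic ring of carbon therefore sits within the scatter of both groups that also carry a five-membered ring, which the earlier pair could not show. No evidence given here accounts for this result.

The compounds shown leave open whether a carboxylic acid or an amine in place of the methylcarbamoyl group would keep the number in this range. As far as these compounds go, whether an unsubstituted phenyl would do so also remains open.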